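A few compounds are considered here, and "the series" means these few. Any claim that something is new, unique, unknown or untested is made for them only; others in the source may bear on it.

Compound 1 `CCN(CC)c1ccc2cc(C(=O)NC(C)C)c(=O)oc2c1`: in a functional assay on HCT-116 cells (Homo sapiens) for cytotoxicity, read by MTT assay, with a stated time of 72 h (on this read-out lower numbers stand for stronger inhibition and higher numbers for weaker inhibition), compound 1 gives > 100000 nM, which is a limit of the assay and not a number.
Compound 2 `CCN(CC)c1ccc2cc(C(=O)NC3CC3)c(=O)oc2c1`: in this assay compound 2 gives > 100000 nM, again a limit of the assay.
Compound 3 `CCN(CC)c1ccc2cc(C(=O)NN)c(=O)oc2c1`: in this assay compound 3 gives 3360 nM.

Going by the values given here, compound 3 therefore holds the only number in this small set, the other two values resting at the limit of > 100000 nM in this assay, at which 2 of the 3 values shown sit. The steps that reach it, an at least 29-fold lower number from compound 1 to compound 3 (1.47 log units; beyond the scatter) and an at least 29-fold lower number from compound 2 to compound 3 (1.47 log units; beyond the scatter), are both large, whereas a step that the two limits leave unreadable from compound 1 to compound 2 cannot be read. Compound 4 `CCN(CC)c1ccc2cc(C(=O)N/N=C(/C)c3cccs3)c(=O)oc2c1` carries a group of 8 heavy atoms (6 carbon, 1 nitrogen, 1 sulfur; one five-membered aromatic ring with 1 hetero atom) in place of one nitrogen atom, on an amide-type nitrogen. Among the compounds with values here, no measured step covers such a change, since the measured ones only concern isopropyl or cyclopropyl giving way to amino. The step is thus expected to be a 2.2-fold lower number from compound 3 to compound 4 (0.35 log units; beyond the scatter), modest in size. Compound 4 is estimated at 1500 nM, with a range from 300 nM to 15000 nM.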

Compound 4, half-maximal inhibitory concentration: > 100000 nM
Compound 4: only a limit was reported; the forecaster's own chance of this, stated with the estimate: 10%; at least 66-fold (1.82 log units) between middle value and limit.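

At this amide-type nitrogen, the larger group with its five-membered aromatic ring in place of amino gives an at least 29-fold higher number from compound 3 to compound 4 (1.47 log units; beyond the scatter), so keeping a nitrogen there is not enough to retain a measurable number. The steps from compound 1 and compound 2 to compound 4 cannot be read, and in this assay compound 3 remains the only compound with a number: the limit of > 100000 nM in this assay, at which 3 of the 4 values shown sit.

As far as these compounds go, whether methylamino or dimethylamino at this nitrogen would keep a number like that of compound 3 stays open. So does whether a phenyl ring in place of the sulfur-containing ring would change the outcome for compound 4.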